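Naphthalenyl for phenyl on the shared core: expected solubility

The compounds below may be only part of what the source reports. "The series", "measured", "known", "first", "only" and "open" are said of these compounds alone.

In a physicochemical assay for solubility, with a stated time of 18 h, at pH 7.4 (on this read-out higher numbers stand for higher solubility and lower numbers for lower solubility), compound 3 `COc1cccc(CNCCCNc2ccnc3cc(-c4ccccc4)ccc23)c1O` gives 32000 nM. Compound 2 `c1ccc(-c2ccc3c(NCCCNCc4ccco4)ccnc3c2)cc1` gives 32000 nM, and compound 1 `COc1cccc(Oc2ccc3c(NCCCNCc4cccc(OC)c4O)ccnc3c2)c1` gives 14500 nM. Compound 3 stands level with compound 2 at the digits shown, the two together the highest of the three, with no change at the digits printed from compound 2 to compound 3 (within the scatter) and a 2.2-fold higher number from compound 1 to compound 3 (0.34 log units; beyond the scatter). Compound 4 `COc1cccc(CNCCCNc2ccnc3cc(-c4cccc5ccccc45)ccc23)c1O` differs from compound 3 by naphthalen-1-yl in place of phenyl on an aromatic carbon. Among the measured compounds shown here, neither measured step swaps phenyl for a larger aromatic group, so no direct precedent exists; the aryl exchange from compound 1 to compound 3 shows such changes can move the number beyond the scatter. Compound 4 is expected to give a lower value, with a step of a 3.2-fold lower number from compound 3 to compound 4 (0.51 log units; beyond the scatter). The estimate for compound 4 is 10000 nM, ranging from 3000 nM to 32000 nM.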

Compound 4, solubility: 32000 nM
Estimate against measurement, compound 4: 3.2-fold (0.51 log units) below; low and high end bracket the measured number.
By their numbers in this assay, from the lowest: compound 1; then compounds 2, 3 and 4 (each within the scatter of the next).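

In this assay, the exchange at this aromatic carbon gives no change at the digits printed from compound 3 to compound 4 (within the scatter), so naphthalen-1-yl, with its 2 six-membered aromatic rings of carbon only, reads alike with phenyl. The step of a 2.2-fold higher number from compound 1 to compound 4 (0.34 log units; beyond the scatter) shows that this group, like phenyl, stands apart from 3-methoxyphenoxy beyond the scatter. Nothing available accounts for this result. Open, from the compounds shown here alone, is whether naphthalen-2-yl at the same carbon would read alike. Also open, going by these compounds, is whether a pyridin-3-yl ring, or a phenyl carrying a carboxylic acid or an amine, would shift the number.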